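Fluoro in place of methoxy: a step among limits

The compounds below may be only part of what the source reports. "The series", "measured", "known", "first", "only" and "open" are said of these compounds alone.

Measured so far in an ADME assay on HepG2 2.2.15 cells (Homo sapiens) for cytotoxicity, read by MTT assay; on this read-out lower numbers stand for higher toxicity in this test and higher numbers for lower toxicity in this test:
- compound 1 `COc1cccc(/C=C/C(=O)Oc2ccc(C(C)=O)cc2)c1` gives > 2780000 nM as a limit
- compound 2 `COc1ccc(/C=C/C(=O)Oc2ccc(C(C)=O)cc2)cc1OC` gives > 2610000 nM as a limit
- compound 3 `COc1cc(/C=C/C(=O)Oc2ccc(C(C)=O)cc2)cc(OC)c1OC` gives > 2420000 nM as a limit

Compound 1 has no exact number here, only the limit > 2780000 nM in this assay, and the other two compounds likewise have only limits. Not yet tested is compound 4 `CC(=O)c1ccc(OC(=O)/C=C/c2cccc(F)c2)cc1`, which differs from compound 1 in one place: fluoro in place of methoxy on an aromatic carbon. This is fluoro in place of methoxy on an aromatic carbon, meta to a large group.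

Among the measured compounds shown here, no tested compound carries fluoro, so the closest guide is what happens when methoxy groups are added. There are two such steps, and each places methoxy in place of hydrogen on an aromatic carbon. For the measured compounds named here, the first is a step that the two limits leave unreadable from compound 1 to compound 2 and the second is a step that the two limits leave unreadable from compound 2 to compound 3 and neither gives a size. Still, all three compounds stayed at limits, with no exact number appearing, so no step beyond the usual scatter is expected for compound 4. The expected change is a step that the limit leaves unreadable from compound 1 to compound 4 in this estimate. The estimated value for compound 4 is 2800000 nM with an expected range from 1200000 nM to 3500000 nM and the result may well be another limit.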

Compound 4, half-maximal cytotoxic concentration: > 3100000 nM
Compound 4: only a limit was reported (the forecaster's own chance of this, stated with the estimate: 80%); middle value at least 1.1-fold (0.04 log units) from the limit.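

Among the compounds shown here, compound 1 and compound 4 both have only limits, so fluoro in place of methoxy gives no step that can be read, and the same holds for the steps among compound 1, compound 2 and compound 3. The compounds shown leave open the actual half-maximal cytotoxic concentration of each compound, and so whether fluoro or methoxy makes any difference to it.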